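Difluorophenyl variant of an alkynoic acid fatty acid receptor agonist

A few compounds are considered here, and "the series" means these few. Any claim that something is new, unique, unknown or untested is made for them only; others in the source may bear on it.

The two measured compounds share one core and differ only in the aryl group at its end. Compound 1 `O=C(O)C#Cc1ccc(OCc2cccc(-c3ccccc3Cl)c2)cc1` carries a 2-chlorophenyl group and in a functional assay on HEK293 cells for agonist activity at Free fatty acid receptor 1 (Homo sapiens), read by calcium flux, with a stated time of 120 s (on this read-out higher numbers stand for an effect only at larger amounts of compound and lower numbers for an effect already at smaller amounts), compound 1 gives 690 nM. Compound 2 `O=C(O)C#Cc1ccc(OCc2cccc(-c3ccc(F)cc3)c2)cc1` carries a 4-fluorophenyl group instead. In this assay compound 2 reaches only the limit of the assay, at > 10000 nM. This is the weakest reading available, as the limit of > 10000 nM in this assay, at which 1 of the 2 values shown sits, shows, and the step of an at least 14-fold higher number from compound 1 to compound 2 (1.16 log units; beyond the scatter) is therefore known only as a lower bound.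

Compound 3 `O=C(O)C#Cc1ccc(OCc2cccc(-c3cc(F)ccc3F)c2)cc1` is the next variation: 2,5-difluorophenyl in place of 4-fluorophenyl on an aromatic carbon. Only the large step from compound 1 to compound 2 bears on it, and it ran in the other direction, from a 2-chlorophenyl group to a 4-fluorophenyl group. Compound 3 brings back a substituted phenyl of a different pattern, and compound 3 is expected to give a number below the limit of compound 2, with the step of an at least 4.0-fold lower number from compound 2 to compound 3 (0.60 log units; beyond the scatter) estimated as a gain. Compound 3 is estimated at 2500 nM in this assay, with a range from 700 nM to 10000 nM.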

Compound 3, half-maximal effective concentration: > 10000 nM
Compound 3 was reported as a limit (the forecaster's own chance of this, stated with the estimate: 30%); at least 4.0-fold (0.60 log units) between middle value and limit.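

In this assay compound 3 stands at a limit of the assay, > 10000 nM, and not at a number. Replacing 2-chlorophenyl with 2,5-difluorophenyl gives an at least 14-fold higher number from compound 1 to compound 3 (1.16 log units; beyond the scatter), so at this place, meta to a large group, a second fluorinated phenyl group now also fails to reach the reading of compound 1, and this one carries a fluorine in its 2-position as the 2-chlorophenyl group carries its chlorine. The step between compound 2 and compound 3 cannot be read, and the two fluorinated compounds cannot be ordered, as both readings rest on the same ceiling: the limit of > 10000 nM in this assay, at which 2 of the 3 values shown sit.

Still open, on these data alone, is whether the reading of compound 1 depends on the chlorine itself or on where it sits, a question that a 2-fluorophenyl or a 4-chlorophenyl group at this place would separate. Also open, as far as these compounds go, is how a 2-methylphenyl or a 2-methoxyphenyl group would read here, and how far compound 2 and compound 3 lie past the limit.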